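The compounds below may be only part of what the source reports. "The series", "measured", "known", "first", "only" and "open" are said of these compounds alone.

Working notes on the series.

Among the measured compounds shown here, compound 1 `O=C(COc1ccc2cc(/C=C3/SC(=O)NC3=O)ccc2c1)Nc1ccccc1` is the only member with a number in an assay on isolated protein for inhibition of histone deacetylase 8 (Homo sapiens), with a stated time of 1 h; a lower number here means a stronger inhibitor, a higher number a weaker inhibitor: compound 1 gives 4500 nM. Compound 2 `Cc1ccc(NC(=O)COc2ccc3cc(/C=C4/SC(=O)NC4=O)ccc3c2)cc1Cl` sits at a limit of the assay, for compound 2 the value is > 50000 nM. Compound 3 `Cc1cc(NC(=O)COc2ccc3cc(/C=C4/SC(=O)NC4=O)ccc3c2)no1` likewise sits at a limit, for compound 3 the value is > 50000 nM. Both changes at the amide-type nitrogen carry the same consequence: an at least 11-fold higher number from compound 1 to compound 2 (1.04 log units; beyond the scatter) and an at least 11-fold higher number from compound 1 to compound 3 (1.04 log units; beyond the scatter), in each case because the limit of > 50000 nM in this assay, at which 2 of the 3 values shown sit, is where the altered compound ends up. The step that the two limits leave unreadable from compound 2 to compound 3 cannot be sized from two limits.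

Compound 4 `O=C(COc1ccc2cc(/C=C3/SC(=O)NC3=O)ccc2c1)Nc1ccccc1Oc1ccccc1` keeps the phenyl on the amide-type nitrogen but alters it: phenoxy in place of hydrogen on an aromatic carbon. For the measured compounds named here, no measured step here changes the phenyl itself, so the closest guidance is that every alteration of this end of compound 1 has so far weakened inhibition by a large margin. The expectation for this assay is therefore a weaker number, a 4.4-fold higher number from compound 1 to compound 4 (0.65 log units; beyond the scatter), with a fair chance that compound 4 also arrives only as a limit. The estimate for compound 4 is 20000 nM, within 5000 nM to 50000 nM.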

Compound 4, half-maximal inhibitory concentration: > 50000 nM
Compound 4: only a limit was reported (the forecaster's own chance of this, stated with the estimate: 35%); at least 2.5-fold (0.39 log units) between middle value and limit.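

Compound 2 already carried added groups on the phenyl and compound 3 carried a 5-methyl-1,2-oxazol-3-yl in its place, so neither showed what a single added group does to this phenyl. Compound 4 does show this: phenoxy in place of hydrogen on an aromatic carbon, ortho to a large group, leaves the rest of compound 1 unchanged and gives an at least 11-fold higher number from compound 1 to compound 4 (1.04 log units; beyond the scatter) in this assay. The loss of a readable number at this end of the series therefore also follows one added phenoxy, and the step gives only a minimum size, set by the limit that compound 4 reaches and not by a measured number: the limit of > 50000 nM in this assay, at which 3 of the 4 values shown sit.

Among the compounds shown here, compounds 2, 3 and 4 all stand at this limit, so they cannot be ordered among themselves, and compound 1 remains the only member with a number. Still open, going by these compounds, is whether a single fluorine atom, a methoxy, an amine or a carboxylic acid on the phenyl would keep a number in this assay, and how far the outcome depends on where on the phenyl such a group sits.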